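Swapping Acetyl for Chloro

The source may report more compounds than this note shows. Statements on the series, on what has been measured and on what is new or still open speak of the compounds shown alone.

Measured compounds:
Compound 1 `Brc1cn2ccnc2c(-c2ccc3ncn(C4CCCCC4)c3c2)n1` gives 10.2% in a functional assay on SK-MEL-2 cells (Homo sapiens) for inhibition, read by sulforhodamine B assay, with a stated time of 48 h, tested at 10 uM; on this read-out lower numbers stand for less inhibition and higher numbers for more inhibition at the one concentration tested (going by the name of the read-out).
Compound 2 `CC(=O)c1ccc(-c2cn3ccnc3c(-c3ccc4ncn(C5CCCCC5)c4c3)n2)cc1` gives 0.58% in this assay.

Among the two measured compounds, compound 2 has the lowest number, and its nearest neighbour is compound 1, whose number is higher by an amount that lies within the scatter. Compound 3 `Clc1ccc(-c2cn3ccnc3c(-c3ccc4ncn(C5CCCCC5)c4c3)n2)cc1` has not yet been measured. It differs from compound 2 in one place: chloro in place of acetyl on an aromatic carbon. Within the data shown here, only one measured step touches this region of the molecule: a number 9.6 percentage points lower from compound 1 to compound 2 (within the scatter), which compares bromo with 4-acetylphenyl and lies within the scatter. The present change keeps the phenyl ring and exchanges the acetyl for a chloro, so compound 2 and compound 3 stay closely alike. Among the measured compounds shown here, both measured numbers sit at the low end of the scale, and no step so far rises beyond the scatter. Compound 3 is therefore expected to show a number 4.4 percentage points higher from compound 2 to compound 3 (within the scatter) in this assay, a shift of no more than the scatter. The estimate for compound 3 is 5%, with a range from -10% to 20%.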

Compound 3, a percentage reported as inhibition, at one concentration (the size of the read-out at that concentration, not a potency): 10.9%
Beside the measured number, compound 3's estimate is 5.9 percentage points below it, within the range that was stated.
By their numbers in this assay, from the lowest: compounds 2, 1 and 3 (each within the scatter of the next, the first and the last beyond it).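

In this assay, among these compounds, exchanging acetyl for chloro on the same aromatic ring gives a number 10.3 percentage points higher from compound 2 to compound 3 (beyond the scatter), a modest change and the first step at this position to go beyond the scatter. The other new step, 4-chlorophenyl in place of bromo, gives a number 0.7 percentage points higher from compound 1 to compound 3 (within the scatter), so adding the chloro-bearing phenyl ring in place of bromo leaves no readable difference, and the group on the ring matters only in the comparison between compound 2 and compound 3, since the step from compound 1 to compound 2 also stays within the scatter. No independent measurement is available to explain these differences.

On these data alone, only acetyl and chloro have been compared on this ring, so it remains open whether an amine, a carboxylic acid or a methoxy group on the same carbon would follow compound 2, follow compound 3 or move the number further. All of these numbers also come from one concentration in one cell line, so they leave open how the compounds would compare at other concentrations or in other cells.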